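The source may hold more compounds than are shown below. What is called first, only, known or untested is meant among the compounds shown, and "the series" means these compounds.

Among the measured compounds shown here, compound 2 `Cc1ccc(O)c(C(=O)NCCCN2CCC[C@@H]3CCCC[C@@H]32)c1` is one of three compounds measured in a functional assay on MDBK cells (Bos taurus) for cytotoxicity; a higher number here means that more compound is tolerated, a lower number that less compound is tolerated. In this assay compound 2 gives > 100 ug/mL, which is a limit of the assay rather than a number. Compound 1 `C[C@@H]1CCC[C@@H]2C[C@@H](NC(=O)c3cc(Cl)ccc3O)CCN21`, which carries a methyl on a saturated ring carbon of its core, gives > 200 ug/mL, again a limit. Compound 3 `O=C(NCCCN1CCC[C@@H]2CCCC[C@@H]21)c1cc(Cl)ccc1O` gives 43 ug/mL. For the measured compounds named here, the one single-point step measured, an at least 2.3-fold lower number from compound 2 to compound 3 (0.36 log units; beyond the scatter), concerns the aromatic carbon, not the saturated ring. Compound 4 `Cc1ccc(O)c(C(=O)NCCCN2[C@H](C)CC[C@@H]3CCCC[C@@H]32)c1` differs from compound 2 by methyl in place of hydrogen on a saturated ring carbon. Going by the values given here, no measured step touches this place, so no change beyond the scatter is expected, and a step that the limit leaves unreadable from compound 2 to compound 4 is the expected step. Compound 4 is therefore estimated at 150 ug/mL, between 60 ug/mL and 400 ug/mL.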

Compound 4, half-maximal cytotoxic concentration: 35 ug/mL
Compound 4: the middle estimate sits 4.3-fold (0.63 log units) above what was measured; the whole stated range lies above it.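

In this assay there is an at least 2.8-fold lower number from compound 2 to compound 4 (0.45 log units; beyond the scatter) when methyl takes the place of hydrogen on a saturated ring carbon next to the ring nitrogen. Among the compounds shown here, this position, which no earlier step touched, therefore responds to a single added carbon, and less compound is tolerated. Only a bound on the step can be given, because compound 2 sits at a limit: the limit of > 100 ug/mL in this assay, at which 1 of the 4 values shown sits.

From the compounds shown here alone, whether an ethyl on this carbon would lower the number further remains open. So does whether the same methyl would lower the number for the chloro compound 3.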